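The compounds below may be only part of what the source reports. "The series", "measured", "known", "first", "only" and "open" are said of these compounds alone.

Within the data shown here, in a functional assay on the whole organism with Rattus norvegicus as the target (a lower number here means that less compound is needed, a higher number that more compound is needed for the effect), compound 1 `COc1ccccc1OCC(O)CNCCC(=O)Nc1ccc(C2=NNC(=O)CC2)cc1` gives 4.3 umol/kg and compound 2 `COc1ccccc1OCC(O)CNCCC(=O)Nc1ccc(C2=NNC(=O)CC2C)cc1` gives 3 umol/kg, which places compound 2 within the scatter of its only measured neighbour. Among the measured compounds shown here, the one measured step, a 1.4-fold lower number from compound 1 to compound 2 (0.16 log units; within the scatter), is a methyl in place of hydrogen on a saturated ring carbon. It does not touch the group that changes next. Compound 3 `Cc1cccc(OCC(O)CNCCC(=O)Nc2ccc(C3=NNC(=O)CC3C)cc2)c1C` differs from compound 2 by 2,3-dimethylphenyl in place of 2-methoxyphenyl on an oxygen on a saturated carbon. For the measured compounds named here, with no measured step covering this change, no shift beyond the scatter is expected in either direction, and the expected step is a 1.3-fold higher number from compound 2 to compound 3 (0.12 log units; within the scatter). For compound 3 the estimate is 4 umol/kg, with an expected range of 1.3 umol/kg to 12 umol/kg.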

Compound 3, dose for half-maximal effect: 2.4 umol/kg
Estimate against measurement, compound 3: 1.7-fold (0.22 log units) above, within the range that was stated.
By their numbers in this assay, from the lowest: compounds 3, 2 and 1 (each within the scatter of the next).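

On an oxygen on a saturated carbon, the exchange of 2-methoxyphenyl for 2,3-dimethylphenyl gives in this assay a 1.3-fold lower number from compound 2 to compound 3 (0.10 log units; within the scatter), so this position can carry an all-carbon aryl group with no shift beyond the scatter. The hydrogen-bond acceptor counted on 2-methoxyphenyl is absent from 2,3-dimethylphenyl, and the number stays within the scatter. No evidence is available on what lies behind this result. From the compounds shown here alone, it remains open whether a naphthyl group, or a phenyl group bearing an amine or a carboxylic acid, would fit here equally well. Going by these compounds, it also remains open whether this step would hold in the absence of the methyl on the saturated ring carbon.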